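Biaryl for stilbene: compound 4 against compound 2

A few compounds are considered here, and "the series" means these few. Any claim that something is new, unique, unknown or untested is made for them only; others in the source may bear on it.

Measured compounds:
compound 1 `COC(=O)/C=C/c1cccc(N(Cc2ccc(/C=C/c3ccccc3F)cc2)C(=O)C2CCCCC2)c1`, 64 nM
compound 2 `COC(=O)/C=C/c1cccc(N(Cc2ccc(/C=C/c3ccccc3F)cc2)C(=O)NC(C)C)c1`, 431 nM
compound 3 `COC/C=C/c1cccc(N(Cc2ccc(/C=C/C(=O)OC(C)(C)C)cc2)C(=O)C2CCCCC2)c1`, 243 nM

Among the three measured compounds, compound 2 gives the highest number in an assay on isolated protein with Bile acid receptor (Homo sapiens) as the target (a lower number here means that less compound is needed, a higher number that more compound is needed for the effect), at 431 nM. Among the compounds with values here, its nearest neighbour is compound 3, which in this assay gives 243 nM, a gap that sits within the scatter; compound 1 lies furthest away at 64 nM, and the only single-point step in the set, a 6.7-fold higher number from compound 1 to compound 2 (0.83 log units; beyond the scatter), connects those two.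

Compound 4 `COC(=O)/C=C/c1cccc(N(Cc2ccc(-c3cccc(Cl)c3)cc2)C(=O)NC(C)C)c1` arises from compound 2 by one change: 3-chlorophenyl in place of 2-(2-fluorophenyl)ethenyl on an aromatic carbon. Within the data shown here, no measured step touches this position, so the expectation rests only on the scale of the one known step and on the position of compound 2 itself. Compound 4 is therefore expected to stay close to compound 2, with a slightly higher number more likely than a lower one, and the estimate for compound 4 is 650 nM, with a range from 200 nM to 2000 nM, meaning an estimated step of a 1.5-fold higher number from compound 2 to compound 4 (0.18 log units; within the scatter).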

Compound 4, half-maximal effective concentration: 1400 nM
Compound 4: the middle estimate sits 2.2-fold (0.33 log units) below what was measured, and the stated range covers the measured number.
By their numbers in this assay, from the lowest: compound 1; then compounds 3 and 2 (each within the scatter of the next); then compound 4.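

Within the data shown here, the 2>4 step is the first reading at this position, on an aromatic carbon para to a large group, and it shows that the position is not indifferent to change: in this assay, 3-chlorophenyl in place of 2-(2-fluorophenyl)ethenyl gives a 3.2-fold higher number from compound 2 to compound 4 (0.51 log units; beyond the scatter). The swap removes the double bond outside aromatic rings and also exchanges fluorine for chlorine and alters the place of the halogen on the ring, so this single step cannot be assigned to any one of these features. Nothing available explains the rise in the number.

The compounds shown leave open how a plain phenyl group or a pyridine ring would read at this position. They also leave open whether the same step would appear with cyclohexyl on the carbonyl carbon, as in compound 1.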